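The compounds below may be only part of what the source reports. "The series", "measured", "known", "first", "only" and "open" are said of these compounds alone.

In a functional assay on HeLa cells (Homo sapiens) for antiproliferative activity, read by CCK-8 assay, with a stated time of 72 h (a lower number here means a stronger inhibitor, a higher number a weaker inhibitor), two compounds have been measured so far:

compound 1 `O=C(Nc1cccc(-c2oc3cc(-c4ccc(F)cc4)ccc3c(=O)c2O)c1)c1ccccc1F` gives 5630 nM
compound 2 `COc1cc(OC)cc(C(=O)Nc2cccc(-c3oc4cc(-c5ccc(F)cc5)ccc4c(=O)c3O)c2)c1` gives 2700 nM

Compound 2 stands at the lower of these two numbers, separated from compound 1 by a 2.1-fold lower number from compound 1 to compound 2 (0.32 log units; beyond the scatter). Compound 3 `O=C(Nc1cccc(-c2oc3cc(-c4ccc(F)cc4)ccc3c(=O)c2O)c1)c1cc(F)cc(F)c1` has not been measured. It differs from compound 2 in one place: 3,5-difluorophenyl in place of 3,5-dimethoxyphenyl on a carbonyl carbon. Among the compounds with values here, no measured step swaps exactly these two groups, so the only guide is a 2.1-fold lower number from compound 1 to compound 2 (0.32 log units; beyond the scatter), which shows a fluorine-bearing ring at this carbonyl carbon giving a higher number than the 3,5-dimethoxyphenyl. Since compound 3 again carries fluorine on that ring, a modest move back toward the number of compound 1 is expected, though the evidence is thin and the outcome could also stay within the scatter of compound 2. Compound 3 is therefore estimated at 4200 nM, with a range from 1500 nM to 12000 nM, which corresponds to an expected step of a 1.6-fold higher number from compound 2 to compound 3 (0.19 log units; within the scatter).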

Compound 3, half-maximal inhibitory concentration: 3380 nM
Compound 3: the middle estimate sits 1.2-fold (0.09 log units) above what was measured; measured number inside the range.
By their numbers in this assay, from the lowest: compounds 2, 3 and 1 (each within the scatter of the next, the first and the last beyond it).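

In this assay, replacing 3,5-dimethoxyphenyl with 3,5-difluorophenyl on the carbonyl carbon gives a 1.3-fold higher number from compound 2 to compound 3 (0.10 log units; within the scatter), so the hydrogen-bond acceptors counted on the leaving ring can go without a change that can be read. The 3,5-difluorophenyl ring also stays close to the 2-fluorophenyl ring, with a 1.7-fold lower number from compound 1 to compound 3 (0.22 log units; within the scatter), which leaves the earlier gap between the 2-fluorophenyl and 3,5-dimethoxyphenyl rings as the only one beyond the scatter and shows that fluorine on this ring does not by itself set the number apart from the 3,5-dimethoxyphenyl compound. Nothing available here explains these numbers.

The compounds shown leave open whether a ring carrying an amine or a carboxylic acid would shift the number beyond the scatter. They also leave open what a longer alkyl chain in place of the ring on this carbonyl carbon would do.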